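The source may report more compounds than this note shows. Statements on the series, on what has been measured and on what is new or still open speak of the compounds shown alone.

Compound 1 `CC(=O)N1CCN(c2ccc(Nc3ncc(C(F)(F)F)c(N4Cc5cccc(N(C)S(C)(=O)=O)c5C4)n3)cc2)CC1` — in a functional assay on U-87MG ATCC cells for antiproliferative activity against U-87 MG (Homo sapiens), read by spectrophotometry, with a stated time of 2 days (on this read-out higher numbers stand for weaker inhibition of growth and lower numbers for stronger inhibition of growth), compound 1 gives 22100 nM.
Compound 3 `CN(c1cccc2c1CN(c1nc(Nc3ccc(Nc4ccccc4)cc3)ncc1C(F)(F)F)C2)S(C)(=O)=O` — in this assay compound 3 gives 29800 nM.
Compound 2 `Cc1ccc(Nc2ncc(C(F)(F)F)c(N3Cc4cccc(N(C)S(C)(=O)=O)c4C3)n2)c(Cl)c1` — in this assay compound 2 returns only a limit of the assay, > 30000 nM.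

Compound 2 therefore has no number of its own; it stands at the limit of > 30000 nM in this assay, at which 1 of the 3 values shown sits, the one limit among the three results. Within the data shown here, the only measured step on the shared core, a 1.3-fold higher number from compound 1 to compound 3 (0.13 log units; within the scatter), lies within the scatter, and both compounds on that step inhibit growth only weakly.

Compound 4 `Cc1cc(Cl)ccc1Nc1ncc(C(F)(F)F)c(N2Cc3cccc(N(C)S(C)(=O)=O)c3C2)n1` is the compound still to be measured. It differs from compound 2 by 4-chloro-2-methylphenyl in place of 2-chloro-4-methylphenyl on a nitrogen on an aromatic ring. Among the measured compounds shown here, no measured step touches the substitution pattern of this phenyl ring, so no measured step bears directly on the change; the most that can be said is that every compound inhibits growth weakly and that compound 2 itself sits at the limit.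

Compound 4 is therefore expected to remain in the weak range, with the step of a number no higher from compound 2 to compound 4 (the limit leaves the size open) expected to be none beyond the scatter. The estimate for compound 4 is 30000 nM, within a range of 10000 nM to 100000 nM.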

Compound 4, concentration for 50% growth inhibition: 28300 nM
Compound 4: middle estimate off by 1.1-fold (0.03 log units), on the high side; the measured number falls inside the stated range.
By their numbers in this assay, from the lowest: compounds 1, 4 and 3 (each within the scatter of the next). At a limit, above all of these: compound 2.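

Among these compounds, exchanging 2-chloro-4-methylphenyl for 4-chloro-2-methylphenyl on this nitrogen gives the first step that touches the substitution pattern of this ring: an at least 1.0-fold lower number from compound 2 to compound 4 (0.02 log units; that floor lies within the scatter) in this assay. Compound 2 has a limit of the assay, not a number: the limit of > 30000 nM in this assay, at which 1 of the 4 values shown sits. The step therefore sets only a floor, and that floor shows no effect of the exchange beyond the scatter. Compound 4 now gives this ring pattern a real value of 28300 nM.

Going by these compounds, the true size of the step stays open, since the value of compound 2 lies beyond the limit. The compounds shown also leave open whether a carboxylic acid or a morpholine on this phenyl ring, or a nitrile in place of the trifluoromethyl on the shared core, would change growth inhibition beyond the scatter.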